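The source may hold more compounds than are shown below. What is called first, only, known or untested is meant among the compounds shown, and "the series" means these compounds.

Measured so far:
compound 1 `N#C[C@@H]1CCCN1C(=O)[C@@H]1C[C@H](C(=O)N2CCOCC2)CN1` — 73%
compound 2 `CCN(C)C(=O)[C@H]1C[C@@H](C(=O)N2CCC[C@H]2C#N)N[C@H]1C` — 92%

Two compounds have been run in an assay on the whole organism (plasma, strain Sprague-Dawley) for inhibition of Dipeptidyl peptidase 4 (Rattus norvegicus), with a stated time of 6 h, at a dose of 1 mg/kg by the oral route; on this read-out higher numbers stand for more inhibition at the one dose given (going by the name of the read-out) and lower numbers for less inhibition. Compound 1 `N#C[C@@H]1CCCN1C(=O)[C@@H]1C[C@H](C(=O)N2CCOCC2)CN1` gives 73%, and compound 2 `CCN(C)C(=O)[C@H]1C[C@@H](C(=O)N2CCC[C@H]2C#N)N[C@H]1C` gives 92%. Compound 1 thus holds the lower of the two numbers, and the gap to compound 2 lies beyond the scatter of this assay. Among the measured compounds shown here, since the two differ at more than one place, no single step between them is counted; the numbers only show that compound 2 sits higher.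

Compound 3 `CCN(C)C(=O)[C@@H]1CN[C@H](C(=O)N2CCC[C@H]2C#N)C1` has not yet been measured. It differs from compound 1 in one place: ethyl(methyl)amino in place of morpholin-4-yl on a carbonyl carbon. The only related data are those of compound 2, which carries the same ethyl(methyl)amino group on a different core and reaches 92%. On that slim basis compound 3 is expected to come out somewhat above compound 1, with the step of a number 9 percentage points higher from compound 1 to compound 3 (within the scatter) estimated to stay within the scatter rather than beyond it. Compound 3 is therefore estimated to give 82% in this assay, in a range from 65% to 95%.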

Compound 3, a percentage reported as inhibition, in the whole organism at one dose (the size of the read-out at that dose, not a potency): 71%
The estimate for compound 3 lay 11 percentage points above the measured number; the range from low to high includes it.
By their numbers in this assay, from the lowest: compounds 3 and 1 (each within the scatter of the next); then compound 2.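

In this assay, ethyl(methyl)amino in place of morpholin-4-yl on a carbonyl carbon gives a number 2 percentage points lower from compound 1 to compound 3 (within the scatter), so this read-out does not separate the open-chain amide from the ring amide at this place on the shared core. The other step gives the first one-place view of the saturated ring carbon: hydrogen in place of methyl there gives a number 21 percentage points lower from compound 2 to compound 3 (beyond the scatter), which shows that ethyl(methyl)amino, present in both compounds, does not by itself go with the higher number of compound 2, whereas the methyl on that saturated ring carbon does in this single pair. Nothing at hand gives a measured reason for either step, so both remain observations of the read-out alone.

What the compounds leave open is whether a piperidin-1-yl or a dimethylamino group on the same carbonyl carbon would also stay within the scatter of morpholin-4-yl. On these data alone, it is also open whether an ethyl group on the saturated ring carbon would keep the number of compound 2, and whether methyl at that place would go with a higher number when morpholin-4-yl sits on the carbonyl carbon.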